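Half-life of compound 4 after replacing methoxy with hydroxy-methylethyl

The compounds below may be only part of what the source reports. "The series", "measured", "known", "first", "only" and "open" are said of these compounds alone.

The series shares one core and differs in the group carried on it. Compound 1 `CC#C[C@@H](Cc1nnn[nH]1)c1ccc(OCc2ccc3scc(-c4cncnc4C)c3c2)cc1`, compound 2 `CC#C[C@@H](Cc1nnn[nH]1)c1ccc(OCc2ccc3scc(-c4ccc(OCCOC)cc4C)c3c2)cc1` and compound 3 `CC#C[C@@H](Cc1nnn[nH]1)c1ccc(OCc2ccc3sc(F)c(-c4ccc(OCCOC)cc4C)c3c2)cc1` have all been measured in an ADME assay on microsomes from liver (Rattus norvegicus) for metabolic stability; a lower number here means that the compound disappears faster, a higher number that the compound lasts longer. Compound 1 gives 0.333 h, compound 2 gives 0.217 h and compound 3 gives 0.35 h. Compound 2 holds the lowest of the three numbers, yet the step of a 1.5-fold lower number from compound 1 to compound 2 (0.19 log units; within the scatter) and the step of a 1.6-fold higher number from compound 2 to compound 3 (0.21 log units; within the scatter) both stay within the scatter, so no ordering among the three can be read from these values.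

Compound 4 `CC#C[C@@H](Cc1nnn[nH]1)c1ccc(OCc2ccc3scc(-c4ccc(OCCC(C)(C)O)cc4C)c3c2)cc1` follows compound 2 with one change: 1-hydroxy-1-methylethyl in place of methoxy on a saturated chain carbon, two bonds along the chain from an oxygen on an aromatic ring. Among the compounds with values here, neither measured step touches this part of the molecule, so no directly comparable step exists; the two that were measured, one on the aromatic substituent and one on the core, each stayed within the scatter. On this basis compound 4 is expected to show a step of a 1.3-fold higher number from compound 2 to compound 4 (0.11 log units; within the scatter) in this assay, with no movement beyond the scatter anticipated. Compound 4 is therefore estimated at 0.28 h, within a range from 0.15 h to 0.55 h.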

Compound 4, half-life: 1.03 h
For compound 4 the middle estimate is 3.7-fold (0.57 log units) below the measured one; measured number above the stated range.
By their numbers in this assay, from the lowest: compounds 2, 1 and 3 (each within the scatter of the next); then compound 4.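

In this assay, the change at this position gives a 4.7-fold higher number from compound 2 to compound 4 (0.68 log units; beyond the scatter) and so is the only step shown here to pass beyond the scatter. The two earlier steps, one on the aromatic substituent and one on the core, showed no such separation, while this one shows that the end of the chain, where 2-methoxyethoxy becomes 3-hydroxy-3-methylbutoxy, is a place where the half-life can move. No measurement at hand bears on why it moves at this position.

The compounds shown leave open whether the step belongs to the hydroxy group or to the added carbons, which a plain 3-methylbutoxy chain or a 3-hydroxypropoxy chain would separate, and how an amine or a carboxylic acid at the same chain end would compare. They also leave open whether the same change gives a similar step with the fluoro of compound 3 on the core.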